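The source may report more compounds than this note shows. Statements on the series, on what has been measured and on what is new or still open speak of the compounds shown alone.

Working notes on the series. The shared core is seen in compound 1 `O=C1/C(=C/c2cccc(Br)c2)NS(=O)(=O)c2ccccc21`, compound 2 `O=C1/C(=C/c2ccc(Br)cc2)NS(=O)(=O)c2ccccc21` and compound 3 `O=C1/C(=C/c2cccc(F)c2)NS(=O)(=O)c2ccccc21`; the three differ only in the group on the double-bonded chain carbon bound to a double-bonded ring carbon. In an assay for inhibition of Intestinal-type alkaline phosphatase (Homo sapiens), read by spectrophotometry, with stated times of 10 min and 20 min (a higher number here means a weaker inhibitor, a lower number a stronger inhibitor), compound 1 gives 2550 nM, compound 2 gives 3690 nM and compound 3 gives 9930 nM. Compound 3 has the highest number of the three: the gap a 2.7-fold higher number from compound 2 to compound 3 (0.43 log units; beyond the scatter) and the gap a 3.9-fold higher number from compound 1 to compound 3 (0.59 log units; beyond the scatter) both lie beyond the scatter, while the positional step a 1.4-fold higher number from compound 1 to compound 2 (0.16 log units; within the scatter) stays within it.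

Compound 4 `Cc1ccccc1/C=C1\NS(=O)(=O)c2ccccc2C1=O` is not yet measured. Within the data shown here, it differs from compound 3 by 2-methylphenyl in place of 3-fluorophenyl on a double-bonded chain carbon bound to a double-bonded ring carbon, so both the ring substituent and its position change at once, and no single measured step covers exactly this move. Among the measured compounds shown here, the steps that bear on it are a 3.9-fold higher number from compound 1 to compound 3 (0.59 log units; beyond the scatter), which shows the fluoro compound as the weakest point so far, and a 1.4-fold higher number from compound 1 to compound 2 (0.16 log units; within the scatter), which shows that moving a substituent around the ring did little. On that basis a modest downward step in this assay is expected from compound 3 to compound 4, a 2.2-fold lower number from compound 3 to compound 4 (0.34 log units; beyond the scatter), with wide uncertainty. Compound 4 is therefore estimated at 4500 nM, with a range from 1500 nM to 13000 nM.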

Compound 4, half-maximal inhibitory concentration: 3750 nM
Beside the measured number, compound 4's estimate is 1.2-fold (0.08 log units) above it; low and high end bracket the measured number.
By their numbers in this assay, from the lowest: compounds 1, 2 and 4 (each within the scatter of the next); then compound 3.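

The group on the double-bonded chain carbon bound to a double-bonded ring carbon need not carry a halogen: in this assay, 2-methylphenyl in place of 3-fluorophenyl gives (a 2.6-fold lower number from compound 3 to compound 4 (0.42 log units; beyond the scatter)), a step beyond the scatter. The 2-methylphenyl compound also stays within the scatter of both bromophenyl compounds (a 1.0-fold higher number from compound 2 to compound 4 (0.01 log units; within the scatter); a 1.5-fold higher number from compound 1 to compound 4 (0.17 log units; within the scatter)), so a carbon-only substituent can stand in for bromo here without a step that can be told from the scatter, and among these four compounds only compound 3 stands apart from the others. No measurement accompanies these numbers that would account for the separation of compound 3.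

The step from compound 3 to compound 4 changes the substituent and its ring position together, so the share of each in the step remains unresolved. Also open is how this place responds to a group of a different kind, such as an amine or a carboxylic acid on the phenyl ring, since every compound shown carries only a halogen or a methyl group there.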